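The source may hold more compounds than are shown below. What is called first, only, known or untested is meant among the compounds shown, and "the series" means these compounds.

Measured compounds:
compound 1 `Cc1cccc(/C(CCN2CCN(c3ccccn3)CC2)=N/O)c1` gives 2.3 nM in a functional assay on HEK293 cells with D(4) dopamine receptor (Homo sapiens) as the target, read by FLIPR; a lower number here means that less compound is needed, a higher number that more compound is needed for the effect
compound 2 `Cc1cccc(/C(=N/O)C(O)CN2CCN(c3ccccn3)CC2)c1` gives 4.9 nM in this assay
compound 3 `COC(CN1CCN(c2ccccn2)CC1)/C(=N/O)c1cccc(C)c1` gives 5370 nM in this assay

Compound 3 stands highest of the three numbers in this assay; against compound 2 it sits far beyond the scatter, and against compound 1 further still. Among the measured compounds shown here, the only step measured, a 2.1-fold higher number from compound 1 to compound 2 (0.33 log units; beyond the scatter), concerns hydroxy in place of hydrogen on a saturated chain carbon and is modest.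

Compound 4 `COC(CN1CCN(c2ccccn2)CC1)/C(=N\O)c1cccc(C)c1` is the next compound for this assay. It differs from compound 3 only in drawn geometry: the two compounds have the same atoms and bonds; at least one stereo element is drawn with a configuration in one of them and without one in the other: 1 of 2 stereo elements differ; a double bond is drawn E in compound 3 and Z in compound 4. For the measured compounds named here, no measured step concerns a change of E to Z at this double bond, so the step from compound 1 to compound 2 does not bear on it, and nothing measured speaks for a direction. The expectation for compound 4 therefore rests on the value of compound 3 alone, with a wide range in both directions. Compound 4 is estimated at 5000 nM, between 1000 nM and 30000 nM. The step from compound 3 to compound 4 is expected to be a 1.1-fold lower number from compound 3 to compound 4 (0.03 log units; within the scatter).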

Compound 4, half-maximal effective concentration: 34.5 nM
The estimate for compound 4 lay 140-fold (2.16 log units) above the measured number; the measured number lies below the stated range.
By their numbers in this assay, from the lowest: compound 1; then compound 2; then compound 4; then compound 3.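

In this assay the geometry of this double bond alone, with atoms and bonds unchanged, gives the largest step in the series, a 160-fold lower number from compound 3 to compound 4 (2.19 log units; beyond the scatter), so the methoxy substituent cannot be judged from compound 3 alone. With the drawing of compound 4, the substituent steps are far smaller, a 7.0-fold higher number from compound 2 to compound 4 (0.85 log units; beyond the scatter) for methyl in place of hydrogen on the oxygen and a 15-fold higher number from compound 1 to compound 4 (1.18 log units; beyond the scatter) for methoxy in place of hydrogen, though both remain beyond the scatter. The geometry comparison carries one caveat: the fact that one of compounds 3 and 4 is drawn with a defined configuration and the other without, at the place where they differ.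

Compounds 1 and 2 appear in one drawn geometry only, leaving open whether the other geometry would shift their numbers as strongly. Also open, from the compounds shown here alone, is whether an ethoxy group or a primary amine on the same chain carbon would follow the hydroxy or the methoxy compounds.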